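The source may hold more compounds than are shown below. What is called first, only, known or untested is meant among the compounds shown, and "the series" means these compounds.

Of the compounds shown here, three sharing one core have been measured in a functional assay on B16 cells (Mus musculus) for cytotoxicity, read by sulforhodamine B assay, with a stated time of 72 h; a lower number here means a stronger inhibitor, a higher number a weaker inhibitor. Compound 1 `OCC#CCSc1cnc2ccccc2c1[Se]CC#CCBr` gives 4.6 ug/mL, compound 2 `OCC#CCSc1cnc2ccccc2c1SCC#CCBr` gives 4.9 ug/mL, and compound 3 `C[Se]c1c(SCC#CCO)cnc2ccccc12` gives 5.8 ug/mL. The steps of a 1.3-fold higher number from compound 1 to compound 3 (0.10 log units; within the scatter) and a 1.2-fold higher number from compound 2 to compound 3 (0.07 log units; within the scatter) both lie within the scatter, as does a 1.1-fold higher number from compound 1 to compound 2 (0.03 log units; within the scatter), so compound 3 stands together with the other two. Compound 4 `C#CC[Se]c1c(SCC#CCO)cnc2ccccc12` carries ethynyl in place of hydrogen on a saturated chain carbon bound to a selenium atom. The step that bears on this is a 1.3-fold higher number from compound 1 to compound 3 (0.10 log units; within the scatter), which also altered the saturated chain carbon bound to a selenium atom; its size gives no reason to expect a step beyond the scatter in this assay in either direction. Compound 4 is therefore estimated at 5.5 ug/mL, between 2.5 ug/mL and 12 ug/mL. The expected step is a 1.1-fold lower number from compound 3 to compound 4 (0.02 log units; within the scatter).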

Compound 4, concentration for 50% inhibition: 6.8 ug/mL
The estimate for compound 4 lay 1.2-fold (0.09 log units) below the measured number; the range from low to high includes it.
By their numbers in this assay, from the lowest: compounds 1, 2, 3 and 4 (each within the scatter of the next).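

In this assay, ethynyl in place of hydrogen on a saturated chain carbon bound to a selenium atom, the change of methyl to propargyl, stays within the scatter (a 1.2-fold higher number from compound 3 to compound 4 (0.07 log units; within the scatter)). Taking off bromomethyl on a triple-bonded carbon (a 1.5-fold higher number from compound 1 to compound 4 (0.17 log units; within the scatter)) and exchanging the sulfur-linked, bromine-bearing group for the selenium-linked propargyl (a 1.4-fold higher number from compound 2 to compound 4 (0.14 log units; within the scatter)) also stay within it, so no change at this position has yet separated these compounds. No supporting measurement bears on these results. From the compounds shown here alone, whether an amine, a carboxylic acid or a longer chain at this position would give a step beyond the scatter remains open.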